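This account rests on a few compounds, and the source may have more. Where it says the series, first, only, none or still open, it means among the compounds named here.

Measured so far:
compound 1 `COc1ccc(-n2nc(C(=O)Nc3ccc(Oc4ccnc5cc(OCCCN6CCCC6)c(OC)cc45)c(F)c3)c(C)cc2=O)cc1` gives 1290 nM in a functional assay on MKN-45 cells (Homo sapiens) for inhibition, read by MTT assay, with a stated time of 72 h; a lower number here means a stronger inhibitor, a higher number a weaker inhibitor
compound 2 `COc1ccc(-n2nc(C(=O)Nc3ccc(Oc4ccnc5cc(OCCCN6CCC(C)CC6)c(OC)cc45)c(F)c3)c(C)cc2=O)cc1` gives 400 nM in this assay

Compound 2 stands at the lowest of the two numbers measured in this assay; its nearest neighbour is compound 1, and the step of a 3.2-fold lower number from compound 1 to compound 2 (0.51 log units; beyond the scatter) lies beyond the scatter.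

Compound 3 `COc1ccc(-n2nc(C(=O)Nc3ccc(Oc4ccnc5cc(OCCCN6CCN(C)CC6)c(OC)cc45)c(F)c3)c(C)cc2=O)cc1` has not yet been measured. It differs from compound 2 in one place: 4-methylpiperazin-1-yl in place of 4-methylpiperidin-1-yl on a saturated chain carbon, three bonds along the chain from an oxygen on an aromatic ring.

Among the measured compounds shown here, the only measured step, a 3.2-fold lower number from compound 1 to compound 2 (0.51 log units; beyond the scatter), exchanges a five-membered ring for a six-membered one on the same chain position; it does not exchange a piperidine for a piperazine, so no measured step bears directly on the change from compound 2 to compound 3. Both rings in that change keep the same size and the same point of attachment. With nothing measured to point one way or the other, a small step is expected, of a size that may well lie within the scatter, with a slight lean toward a higher number. For compound 3 the expected step is a 1.4-fold higher number from compound 2 to compound 3 (0.14 log units; within the scatter). Compound 3 is therefore estimated at 550 nM in this assay, within a range from 200 nM to 1500 nM.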

Compound 3, half-maximal inhibitory concentration: 1230 nM
Estimate against measurement, compound 3: 2.2-fold (0.35 log units) below; the measured number falls inside the stated range.
By their numbers in this assay, from the lowest: compound 2; then compounds 3 and 1 (each within the scatter of the next).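

In this assay, the exchange of 4-methylpiperidin-1-yl for 4-methylpiperazin-1-yl (a 3.1-fold higher number from compound 2 to compound 3 (0.49 log units; beyond the scatter)) shows that the number at this chain end can move even when ring size and heavy-atom count stay the same and one ring carbon gives way to a nitrogen. Ring size alone therefore does not set the number here: compound 3 carries a six-membered ring like compound 2, yet it sits level with the five-membered pyrrolidin-1-yl of compound 1 (a 1.0-fold lower number from compound 1 to compound 3 (0.02 log units; within the scatter)), so the gain seen with compound 2 belongs to the 4-methylpiperidin-1-yl group in this set, not to six-membered rings in general. Nothing measured here explains why the second ring nitrogen goes with the higher number.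

Going by these compounds, it remains open whether a morpholin-4-yl group or an unsubstituted piperidin-1-yl group at the same place would fall with compound 2 or with compounds 1 and 3. Also open, on these data alone, is whether the number of compound 2 would hold with a shorter chain, as in 2-(4-methylpiperidin-1-yl)ethyl.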